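The source may hold more compounds than are shown below. What is called first, only, known or untested is meant among the compounds shown, and "the series" means these compounds.

Compound 1, `COc1cc2c(cc1OC)C(CC(=O)N(C)C)CC2`, gives 33.3% in a functional assay on the whole organism (strain Wistar) for inhibition, with Rattus norvegicus as the target, read by paw edema, with stated times of 60 min and 6 h, at a dose of 100 mg/kg by the oral route; a higher number here means more inhibition at the dose given (going by the name of the read-out), a lower number less inhibition.
Compound 2, `COc1cc2c(cc1OC)C(CC(=O)NC(C)C)CC2`, gives 37%.
Compound 3, `COc1cc2c(cc1OC)C(CC(=O)N1CCCCC1)CC2`, gives 31.5%.

All three share one core and differ only in the group attached to the carbonyl carbon of the amide. Compound 3 carries the lowest of the three numbers, yet each step leading to it stays within the usual scatter: a number 1.8 percentage points lower from compound 1 to compound 3 (within the scatter) and a number 5.5 percentage points lower from compound 2 to compound 3 (within the scatter). The remaining pair behaves the same way: a number 3.7 percentage points higher from compound 1 to compound 2 (within the scatter). Across these three compounds, swapping one amide substituent for another has not moved the read-out beyond what repeated measurements of this kind already vary by.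

Compound 4, `COc1cc2c(cc1OC)C(CC(=O)N1CCOCC1)CC2`, continues this same kind of change: morpholin-4-yl in place of piperidin-1-yl on a carbonyl carbon. Among the compounds with values here, the steps that bear on it are the three amide swaps just described, all within the scatter. Within the data shown here, nothing among the measured compounds shows what the added ring oxygen does on its own. The expectation is therefore a step of about a number 0.5 percentage points higher from compound 3 to compound 4 (within the scatter) in this assay, meaning no change beyond the scatter. Compound 4 is estimated at 32%, with a range from 22% to 42%.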

Compound 4, a percentage reported as inhibition, in the whole organism at one dose (the size of the read-out at that dose, not a potency): 14.8%
Estimate against measurement, compound 4: 17.2 percentage points above, outside the stated range (below it).
By their numbers in this assay, from the lowest: compound 4; then compounds 3, 1 and 2 (each within the scatter of the next).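

In this assay this position on a carbonyl carbon gives its first step beyond the scatter, with a number 16.7 percentage points lower from compound 3 to compound 4 (beyond the scatter) and the same picture against the two open-chain amides, namely a number 22.2 percentage points lower from compound 2 to compound 4 (beyond the scatter) and a number 18.5 percentage points lower from compound 1 to compound 4 (beyond the scatter) as well. The position therefore does respond to the group placed on it, even though the ring size and the count of heavy atoms stay the same from piperidin-1-yl to morpholin-4-yl, and a single ring atom is what separates the two groups. No measurement at hand explains why this swap lowers the number.

The compounds shown leave open whether the lower number belongs to the ring oxygen itself or to any second ring hetero atom, which a piperazin-1-yl or thiomorpholin-4-yl group on the same carbonyl carbon could test. From the compounds shown here alone, whether the gap holds at other doses also stays open.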